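The source may report more compounds than this note shows. Statements on the series, on what has been measured and on what is new or still open speak of the compounds shown alone.

Measured compounds:
Compound 1 `NC(=O)c1c(NC(=O)c2ccccc2Cl)sc2c1CCN(C(=S)Nc1ccccc1C(F)(F)F)C2` gives 10600 nM in a functional assay on HL-60 cells (Homo sapiens) for antiproliferative activity, with a stated time of 24 h; a higher number here means a weaker inhibitor, a lower number a stronger inhibitor.
Compound 2 `NC(=O)c1c(NC(=O)c2ccccc2Cl)sc2c1CCN(C(=S)Nc1ccccc1-c1ccccc1)C2` gives 34400 nM in this assay.
Compound 3 `NC(=O)c1c(NC(=O)c2ccccc2Cl)sc2c1CCN(C(=S)Nc1ccc(C(F)(F)F)cc1)C2` gives 7590 nM in this assay.

Compound 3 has the lowest number of the three. Its nearest neighbour is compound 1, as a 1.4-fold lower number from compound 1 to compound 3 (0.15 log units; within the scatter) shows, a step within the scatter; its furthest is compound 2, with a 4.5-fold lower number from compound 2 to compound 3 (0.66 log units; beyond the scatter). The other measured step, a 3.2-fold higher number from compound 1 to compound 2 (0.51 log units; beyond the scatter), also concerns the aryl group on the thiourea nitrogen.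

Compound 4 `NC(=O)c1c(NC(=O)c2ccc(C(F)(F)F)cc2)sc2c1CCN(C(=S)Nc1ccc(C(F)(F)F)cc1)C2` differs from compound 3 at a different position: 4-(trifluoromethyl)phenyl in place of 2-chlorophenyl on a carbonyl carbon. For the measured compounds named here, none of the measured steps touches the group on the carbonyl carbon; all three steps vary the aryl on the thiourea nitrogen while the 2-chlorophenyl amide is kept. So no measured step bears directly on this change, and the data give no ground for predicting a shift in either direction. The expectation is therefore a number for compound 4 close to that of compound 3, with the step of a 1.0-fold higher number from compound 3 to compound 4 (0.00 log units; within the scatter) expected to stay within the scatter, and a wide range to reflect the lack of a relevant precedent. Compound 4 is estimated at 7600 nM in this assay, expected between 2500 nM and 25000 nM.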

Compound 4, half-maximal inhibitory concentration: 5520 nM
Beside the measured number, compound 4's estimate is 1.4-fold (0.14 log units) above it; the range from low to high includes it.
By their numbers in this assay, from the lowest: compounds 4, 3 and 1 (each within the scatter of the next); then compound 2.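

For the compounds shown here, compound 4 gives the first reading at the carbonyl carbon, where the earlier compounds all carried 2-chlorophenyl. In this assay, putting 4-(trifluoromethyl)phenyl in place of 2-chlorophenyl gives a 1.4-fold lower number from compound 3 to compound 4 (0.14 log units; within the scatter), a step within the scatter, so compound 3 and compound 4 cannot be told apart here. The position therefore accepts this exchange of one substituted phenyl for another without a measurable shift, at least while 4-(trifluoromethyl)phenyl stays on the amide-type nitrogen, and no supporting measurement is available to explain that outcome.

Because both groups shown at this position are substituted phenyl rings, it remains open how a 4-chlorophenyl, an unsubstituted phenyl, a ring carrying an amine or a carboxylic acid, or a saturated alkyl chain would behave on the carbonyl carbon. As far as these compounds go, it is also open whether the same exchange would remain within the scatter alongside the other groups on the amide-type nitrogen, such as the 2-phenylphenyl of compound 2, since this single step was read against only one partner.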